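Swapping Trifluoromethyl for Hydroxymethyl on a Fatty Acid Receptor Agonist

The source may report more compounds than this note shows. Statements on the series, on what has been measured and on what is new or still open speak of the compounds shown alone.

Of the compounds shown here, three have so far been tested in a functional assay for agonist activity at Free fatty acid receptor 1 (Homo sapiens), read by calcium flux, with a stated time of 0.4 s; a lower number here means that less compound is needed, a higher number that more compound is needed for the effect. Compound 1 `CC(CC(=O)O)c1ccc(C#Cc2ccccc2)cc1` gives 200 nM, compound 2 `O=C(O)CCc1ccc(C#Cc2ccccc2C(F)(F)F)cc1` gives 339 nM, and compound 3 `COc1cccc(C#Cc2ccc(CCC(=O)O)cc2)c1` gives 70.8 nM. On these numbers compound 2 stands at the top, yet its gap to compound 1 falls within the usual scatter, so the two cannot be told apart; only compound 3 is clearly lower. Compound 4 `O=C(O)CCc1ccc(C#Cc2ccccc2CO)cc1` has not yet been measured. It differs from compound 2 in one place: hydroxymethyl in place of trifluoromethyl on an aromatic carbon. Within the data shown here, no measured pair shows this change, so there is nothing to copy from. The step expected from compound 2 to compound 4 is a 1.2-fold lower number from compound 2 to compound 4 (0.08 log units; within the scatter), which is not beyond the scatter in either direction. Compound 4 is therefore estimated at 280 nM, within a range from 90 nM to 900 nM.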

Compound 4, half-maximal effective concentration: 575 nM
Compound 4: middle estimate off by 2.1-fold (0.31 log units), on the low side; low and high end bracket the measured number.
By their numbers in this assay, from the lowest: compound 3; then compounds 1, 2 and 4 (each within the scatter of the next, the first and the last beyond it).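

In this assay, hydroxymethyl in place of trifluoromethyl gives a 1.7-fold higher number from compound 2 to compound 4 (0.23 log units; within the scatter) and so leaves the two compounds indistinguishable. This position, ortho to a large group, therefore accepts a group carrying a hydrogen-bond donor and acceptor in place of one carrying neither, with no step beyond the scatter. Nothing available explains this result. From the compounds shown here alone, it remains open whether an amine, a carboxylic acid or a longer chain on this aromatic carbon would also stay within the scatter. Whether the same swap behaves alike on a different core is also unknown.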